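Sulfonyl substituent variation: methoxyamino in place of methyl

The source may report more compounds than this note shows. Statements on the series, on what has been measured and on what is new or still open speak of the compounds shown alone.

Compound 2 `CC(C)N/[N+]([O-])=N/OCCS(C)(=O)=O` gives 15.3 h in a physicochemical assay for metabolic stability, read by spectrophotometry, in phosphate buffer, at pH 7.4 (a lower number here means that the compound disappears faster, a higher number that the compound lasts longer), and compound 1 `COS(=O)(=O)CCO/N=[N+](\[O-])NC(C)C` gives 17.1 h in this assay, the two numbers lying within the scatter of each other: a 1.1-fold lower number from compound 1 to compound 2 (0.05 log units; within the scatter). Compound 3 `CONS(=O)(=O)CCO/N=[N+](\[O-])NC(C)C` carries methoxyamino in place of methyl on a sulfonyl sulfur. Within the data shown here, the only measured step that bears on this position is the one from compound 1 to compound 2, which also exchanged the group on the sulfonyl sulfur and did not move the half-life beyond the scatter. The step expected from compound 2 to compound 3 is therefore a 1.0-fold lower number from compound 2 to compound 3 (0.01 log units; within the scatter), nothing beyond the scatter. Compound 3 is estimated at 15 h, range 7 h to 32 h.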

Compound 3, half-life: 8.9 h
The estimate for compound 3 lay 1.7-fold (0.23 log units) above the measured number, within the range that was stated.
By their numbers in this assay, from the lowest: compounds 3, 2 and 1 (each within the scatter of the next).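

Methoxyamino on a sulfonyl sulfur brings a hydrogen-bond donor that methyl lacks, yet it gives a 1.7-fold lower number from compound 2 to compound 3 (0.24 log units; within the scatter) in this assay and stays within the scatter of the methyl compound. The step from methoxy reads a 1.9-fold lower number from compound 1 to compound 3 (0.28 log units; within the scatter) and is likewise no separation, so the half-life does not tell the three groups shown on this sulfur apart. Nothing at hand explains these half-lives. Still open, on these data alone, is whether an amine, a carboxylic acid or a longer chain on this sulfur would give a step beyond the scatter.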